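Methoxy added to the phenyl of compound 3

The source may report more compounds than this note shows. Statements on the series, on what has been measured and on what is new or still open speak of the compounds shown alone.

Compound 3 `O=C(O)CCc1ccc(OCc2nc(-c3ccccc3)no2)cc1` gives 1130 nM in a functional assay on CHO cells for agonist activity at Free fatty acid receptor 1 (Homo sapiens), read by FLIPR and calcium flux, in the presence of a further agent that is not named here (a higher number here means that more compound is needed for the effect, a lower number that less compound is needed), the lowest of the three numbers in hand. Compound 1 `O=C(O)CCc1ccc(OCc2ncc(-c3ccccc3)o2)cc1` gives 1600 nM in this assay, within the scatter of compound 3. Compound 2 `O=C(O)CCc1ccc(OCc2nc(-c3cccc(C(F)(F)F)c3)no2)c(Cl)c1` gives 30100 nM in this assay, a far higher number than compound 3; compound 2 differs from compound 3 in more than one place, so its two values say nothing about either change alone. Compound 4 `COc1cccc(-c2noc(COc3ccc(CCC(=O)O)cc3)n2)c1` carries the change (methoxy in place of hydrogen on an aromatic carbon), methoxy in place of hydrogen on an aromatic carbon, meta to a large group. Among the compounds with values here, no single-point step of this kind has been measured, so a modest step, or none beyond the scatter, is expected. Compound 4 is estimated at 1500 nM, within 500 nM to 5000 nM, the expected step being a 1.3-fold higher number from compound 3 to compound 4 (0.12 log units; within the scatter).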

Compound 4, half-maximal effective concentration: 2670 nM
For compound 4 the middle estimate is 1.8-fold (0.25 log units) below the measured one, and the stated range covers the measured number.
By their numbers in this assay, from the lowest: compounds 3, 1 and 4 (each within the scatter of the next, the first and the last beyond it); then compound 2.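

Phenyl to 3-methoxyphenyl gives the first single-place step in the series in this assay, a 2.4-fold higher number from compound 3 to compound 4 (0.37 log units; beyond the scatter), a modest change. On this aromatic carbon, meta to a large group, methoxy in place of hydrogen therefore raises the number without a large loss. No measurement available here accounts for the step.

Going by these compounds, whether a hydroxyl, an amine or an ethoxy group on this same carbon would give a similar step remains open. So does the effect of methoxy on the other carbons of this ring.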